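Methoxy for Chloro in an Ovarian Cell Growth Series

The source may report more compounds than this note shows. Statements on the series, on what has been measured and on what is new or still open speak of the compounds shown alone.

Of the compounds shown here, three have been measured in a functional assay on OVCAR-3 cells (Homo sapiens); on this read-out higher numbers stand for weaker inhibition of growth and lower numbers for stronger inhibition of growth. Compound 1 `Cc1cnc2nc(-c3ccc(F)cc3)cc(O)c2c1` gives 22400 nM, compound 2 `Cc1cc(C)c2c(O)cc(-c3ccc(Cl)cc3)nc2n1` gives 18200 nM, and compound 3 `COc1cccc(-c2cc(O)c3cccnc3n2)c1` gives 55 nM. Compound 2 thus stands second highest of the three numbers; its nearest neighbour is compound 1, whose value lies within the scatter of compound 2, and the furthest is compound 3, which sits far lower, beyond the scatter. Compound 3 differs from compound 2 in more than one place, so its value alone does not tell what a single change is worth.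

Compound 4 `COc1ccc(-c2cc(O)c3c(C)cc(C)nc3n2)cc1` has not yet been measured in this assay. It differs from compound 2 in one place only: methoxy in place of chloro on an aromatic carbon. Among the measured compounds shown here, no step between two measured compounds isolates this change. Given the wide gap between compound 2 and compound 3, some movement toward lower numbers is expected, but only a modest one, since other differences separate those two. Compound 4 is therefore estimated at 8000 nM, with a range from 1500 nM to 30000 nM, which corresponds to an expected step of a 2.3-fold lower number from compound 2 to compound 4 (0.36 log units; beyond the scatter).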

Compound 4, concentration for 50% growth inhibition: 32400 nM
Beside the measured number, compound 4's estimate is 4.1-fold (0.61 log units) below it, outside the stated range (above it).
By their numbers in this assay, from the lowest: compound 3; then compounds 2, 1 and 4 (each within the scatter of the next).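

Among the compounds shown here, for the position para to a large group, this is the first single change that can be read: a 1.8-fold higher number from compound 2 to compound 4 (0.25 log units; within the scatter) in this assay, so on this core methoxy in place of chloro leaves the read-out within the scatter. At this place, the extra heavy atom and the hydrogen-bond acceptor that enter with methoxy come with no change that can be told from the scatter of repeated measurements. Nothing shown gives a reason for this result.

Which of its several differences goes with the low number of compound 3 , at 55 nM in this assay, stays open, as no single step reaches that compound. Also open, as far as these compounds go, is whether an amine or a carboxylic acid on this same aromatic carbon would leave the number where it stands or move it.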